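The source may report more compounds than this note shows. Statements on the series, on what has been measured and on what is new or still open speak of the compounds shown alone.

Measured in a functional assay on A549 cells (Homo sapiens) for cytotoxicity, read by MTT assay, with a stated time of 72 h; on this read-out higher numbers stand for weaker inhibition and lower numbers for stronger inhibition:
compound 1 `Cc1cccc(Cl)c1NC(=O)CN1CCN(c2nnc(Cc3ccncc3)c3ccccc23)CC1` gives 7190 nM
compound 2 `O=C(CN1CCN(c2nnc(Cc3ccncc3)c3ccccc23)CC1)Nc1ccc(F)c(F)c1` gives 3790 nM
compound 3 `O=C(CN1CCN(c2nnc(Cc3ccncc3)c3ccccc23)CC1)Nc1ccc(F)c(Cl)c1` gives 12300 nM

Compound 2 holds the lowest of the three numbers shown. Its gap to compound 1 stays within the scatter (a 1.9-fold lower number from compound 1 to compound 2 (0.28 log units; within the scatter)), whereas compound 3 lies clearly higher (a 3.2-fold higher number from compound 2 to compound 3 (0.51 log units; beyond the scatter)). Compound 4 `O=C(CN1CCN(c2nnc(Cc3ccncc3)c3ccccc23)CC1)Nc1cccc(F)c1` follows from compound 2 by hydrogen in place of fluoro on an aromatic carbon.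

Within the data shown here, no measured step removes a halogen from this position outright. Among the measured compounds shown here, the only step that touches the same carbon, a 3.2-fold higher number from compound 2 to compound 3 (0.51 log units; beyond the scatter), exchanges one halogen for another and was modest. The two exchanges of the whole aryl ring, a 1.9-fold lower number from compound 1 to compound 2 (0.28 log units; within the scatter) and a 1.7-fold higher number from compound 1 to compound 3 (0.23 log units; within the scatter), both remained within the scatter. On this basis the expected step for compound 4 is none beyond the scatter, with a slight lean toward a higher number: a 1.3-fold higher number from compound 2 to compound 4 (0.10 log units; within the scatter). Compound 4 is therefore estimated at 4800 nM in this assay, with a range of 2000 nM to 11500 nM.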

Compound 4, half-maximal inhibitory concentration: 4600 nM
Beside the measured number, compound 4's estimate is 1.0-fold (0.02 log units) above it, and the stated range covers the measured number.
By their numbers in this assay, from the lowest: compounds 2, 4, 1 and 3 (each within the scatter of the next, the first and the last beyond it).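

In this assay, the step at the carbon para to a large group is now read directly: hydrogen in place of fluoro gives a 1.2-fold higher number from compound 2 to compound 4 (0.08 log units; within the scatter), so the 3,4-difluorophenyl and 3-fluorophenyl amides are not separated and this fluoro is not needed to keep the number of compound 2. The 3-chloro-4-fluorophenyl amide stands apart from the 3-fluorophenyl amide, with a 2.7-fold lower number from compound 3 to compound 4 (0.43 log units; beyond the scatter), so compound 3 is now beyond the scatter of two of the fluorinated compounds. Compound 1 is not separated from the new compound either, with a 1.6-fold lower number from compound 1 to compound 4 (0.19 log units; within the scatter).

No measurement shown explains the size of these steps. As far as these compounds go, whether a methoxy group, a nitrile or an amine on this carbon would move the number beyond the scatter of compound 4 remains open.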